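Fluoro on the chlorophenyl ring of compound 2

A few compounds are considered here, and "the series" means these few. Any claim that something is new, unique, unknown or untested is made for them only; others in the source may bear on it.

Of the compounds shown here, two have numbers so far in a physicochemical assay for solubility, read by nephelometry, measured as kinetic solubility, at pH 6.5; a lower number here means a less soluble compound, a higher number a more soluble compound. Compound 1 (`N#Cc1ccc(C(O)(c2ccc(C(F)(F)F)cc2)c2cccnc2)cc1`) gives 6.3 ug/mL. Compound 2 (`NC(=O)c1cccc(C(O)(c2ccc(Cl)cc2)c2cccnc2)c1`) gives 50 ug/mL, the higher of the two numbers, and the gap between them lies beyond the scatter. The pair differs in more than one place, so it cannot be read as the result of any single change.

Compound 3 (`NC(=O)c1cccc(C(O)(c2cccnc2)c2ccc(Cl)cc2F)c1`) keeps compound 2 intact except for one site, where 4-chlorophenyl becomes 4-chloro-2-fluorophenyl: fluoro in place of hydrogen on an aromatic carbon, ortho to a large group and meta to a chloro group (fluoro in place of hydrogen on an aromatic carbon). Within the data shown here, no measured step covers this change, so the expectation rests on the structural change alone. With only this one substitution, a small move is expected in this assay, slightly downward if anything and not beyond the scatter. The expected move is a 1.3-fold lower number from compound 2 to compound 3 (0.10 log units; within the scatter). Compound 3 is estimated at 40 ug/mL, with an expected range of 16 ug/mL to 90 ug/mL.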

Compound 3, solubility: 50 ug/mL
For compound 3 the middle estimate is 1.3-fold (0.10 log units) below the measured one, within the range that was stated.
By their numbers in this assay, from the lowest: compound 1; then compounds 2 and 3 (each within the scatter of the next).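

The series now has its first step at a single site: in this assay, fluoro in place of hydrogen on an aromatic carbon, ortho to a large group and meta to a chloro group, gives no change at the digits printed from compound 2 to compound 3 (within the scatter). Compound 1 and compound 2 differ in more than one place and could not speak to any one position, whereas this pair isolates one site and shows that, in this setting, adding a single fluoro there produces no step beyond the scatter. No measured information bears on why the read-out behaves this way at this site.

From the compounds shown here alone, this is one substituent at one position on one background, so it remains open whether the same holds for a larger group at this site, such as methoxy or an amine, or for fluoro elsewhere on the ring. Also open, going by these compounds, is how this assay responds to a single change at the other sites of compound 3, for example a carboxylic acid in place of the amide or a hydrogen in place of the chloro group.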